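The source may report more compounds than this note shows. Statements on the series, on what has been measured and on what is new or still open speak of the compounds shown alone.

Measured so far:
compound 1, `CC(C)[C@H](NC(=O)COc1cccc2ccccc12)C(=O)N[C@@H](CC(=O)O)C(=O)CSc1nc(-c2ccccc2)c(-c2ccccc2)[nH]1`, > 200000 nM
compound 2, `CC(C)[C@H](NC(=O)COc1cccc2ccccc12)C(=O)N[C@@H](CC(=O)O)C(=O)CSc1nnc(-c2ccccc2)o1`, 150000 nM

Both compounds share the same core and differ only in the group on the saturated chain carbon bound to a carbonyl carbon. In a functional assay on Jurkat cells (Homo sapiens) for inhibition (on this read-out lower numbers stand for stronger inhibition and higher numbers for weaker inhibition), compound 1 reaches only a limit of the assay, > 200000 nM, and no number. In this assay, going by the values given here, compound 2 gives 150000 nM, the only number in hand; the remaining value is the limit of > 200000 nM in this assay, at which 1 of the 2 values shown sits. Compound 2 thus sits at the weak end of what this assay resolves.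

Compound 3, `CC(C)[C@H](NC(=O)COc1cccc2ccccc12)C(=O)N[C@@H](CC(=O)O)C(=O)COc1ccncn1`, differs from compound 2 by (pyrimidin-4-yl)oxy in place of (5-phenyl-1,3,4-oxadiazol-2-yl)sulfanyl on a saturated chain carbon bound to a carbonyl carbon. Among the compounds with values here, no step between measured compounds is available, so the size of this change is unanchored. The step expected from compound 2 to compound 3 in this assay, a 1.5-fold lower number from compound 2 to compound 3 (0.18 log units; within the scatter), is judged small, not clearly beyond the scatter. For compound 3 the estimated value in this assay is 100000 nM, expected to fall between 20000 nM and 400000 nM.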

Compound 3, half-maximal inhibitory concentration: > 200000 nM
Compound 3 ended at the assay's limit; the forecaster's own chance of this, stated with the estimate: 35%; middle value at least 2.0-fold (0.30 log units) away from the limit.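

In this assay, (pyrimidin-4-yl)oxy in place of (5-phenyl-1,3,4-oxadiazol-2-yl)sulfanyl on a saturated chain carbon bound to a carbonyl carbon gives an at least 1.3-fold higher number from compound 2 to compound 3 (0.12 log units; that floor lies within the scatter). As far as these compounds go, this step is only a floor, so its true size stays unknown, but the change to the smaller group brings no recovery of inhibition on this read-out. With the groups of compound 1, compound 2 and compound 3, this place has now given no value away from the weak end of the range in this assay, and the limit recurs: the limit of > 200000 nM in this assay, at which 2 of the 3 values shown sit.

The compounds shown leave open how far compound 3 actually lies from compound 2, and whether any group at this place can give a clearly lower number. A benzoyloxy group or a simple amine on the same chain carbon would test that.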